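Swapping Trifluoromethyl for Fluoro on a Second Core

The source may report more compounds than this note shows. Statements on the series, on what has been measured and on what is new or still open speak of the compounds shown alone.

Compound 1 `CCC(c1nc2ncc(Cl)cc2[nH]1)[C@H]1CC[C@@H](c2ccnc3ccc(C(F)(F)F)cc32)CC1` carries a trifluoromethyl group on its outer aromatic ring; in an assay on blood for inhibition of Indoleamine 2,3-dioxygenase 1 (Homo sapiens), read by mass spectrometry, with a stated time of 18 h (a higher number here means a weaker inhibitor, a lower number a stronger inhibitor), compound 1 gives 21 nM. Compound 3 `CCC(c1nc2ncc(Cl)cc2[nH]1)[C@H]1CC[C@@H](c2ccnc3ccc(F)cc32)CC1` differs from it in one place only, (fluoro in place of trifluoromethyl on an aromatic carbon), and in this assay compound 3 gives 6 nM, so that a 3.5-fold lower number from compound 1 to compound 3 (0.54 log units; beyond the scatter). Compound 2 `CCC(Nc1nnc(-c2ccc(OC)cc2)o1)[C@H]1CC[C@@H](c2ccnc3ccc(C(F)(F)F)cc32)CC1` is built on a different core; the difference between the two cores is not broken down here. In this assay compound 2 gives 50 nM, the highest of the three numbers. Compound 4 `CCC(Nc1nnc(-c2ccc(OC)cc2)o1)[C@H]1CC[C@@H](c2ccnc3ccc(F)cc32)CC1` has not yet been measured; it stands to compound 2 exactly as compound 3 stands to compound 1, the same change, (fluoro in place of trifluoromethyl on an aromatic carbon). The earlier step, a 3.5-fold lower number from compound 1 to compound 3 (0.54 log units; beyond the scatter), is the basis for the expectation here. Compound 4 is therefore expected to make a step of a 3.3-fold lower number from compound 2 to compound 4 (0.52 log units; beyond the scatter). Compound 4 is estimated at 15 nM in this assay, with a likely range from 6 nM to 40 nM.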

Compound 4, half-maximal inhibitory concentration: 16 nM
Compound 4: middle estimate off by 1.1-fold (0.03 log units), on the low side, within the range that was stated.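

On the core of compound 2, replacing trifluoromethyl with fluoro gives a 3.1-fold lower number from compound 2 to compound 4 (0.49 log units; beyond the scatter) in this assay. Among these compounds, the change therefore carried over from one core to the other at about the same size, with the two steps agreeing: the same change on two cores in this assay, a 3.5-fold lower number (0.54 log units; beyond the scatter) from compound 1 to compound 3 and a 3.1-fold lower number (0.49 log units; beyond the scatter) from compound 2 to compound 4, 1.1-fold (0.05 log units) apart, within the scatter of two such steps This is still one change on only two cores, so it does not show that the step would hold on every core, nor why fluoro gives the lower number.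

The compounds shown leave open what other groups on that aromatic carbon, such as chloro, nitrile or a plain hydrogen, would do. They also leave open whether the step would survive on a core carrying an amine or a carboxylic acid.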